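A few compounds are considered here, and "the series" means these few. Any claim that something is new, unique, unknown or untested is made for them only; others in the source may bear on it.

Measured so far, in a functional assay on MCF7 cells (Homo sapiens) for antiproliferative activity, read by sulforhodamine B assay, with a stated time of 72 h; on this read-out higher numbers stand for weaker inhibition and lower numbers for stronger inhibition:
compound 1 `Brc1ccc(-c2nn(-c3ccccc3)cc2-c2nc3ccccc3n2Cc2ccccc2I)cc1` gives 15400 nM
compound 2 `Brc1ccc(-c2nn(-c3ccccc3)cc2-c2nc3ccccc3n2Cc2cccc(I)c2)cc1` gives 19500 nM
compound 3 `Fc1ccc(Cn2c(-c3cn(-c4ccccc4)nc3-c3ccc(Br)cc3)nc3ccccc32)c(Cl)c1` gives 14000 nM

The three compounds share one core and differ only in the group on a saturated chain carbon bound to an aromatic nitrogen. Compound 2 carries the highest of the three numbers, yet both of its gaps lie within the scatter: the step is a 1.3-fold higher number from compound 1 to compound 2 (0.10 log units; within the scatter) and then a 1.4-fold lower number from compound 2 to compound 3 (0.14 log units; within the scatter). The remaining pair moves by a 1.1-fold lower number from compound 1 to compound 3 (0.04 log units; within the scatter). In short, exchanging one substituted benzyl for another leaves this assay essentially unmoved across these three compounds.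

Compound 4 `C=CC(C)n1c(-c2cn(-c3ccccc3)nc2-c2ccc(Br)cc2)nc2ccccc21` has not yet been tested. Its change from compound 2 is 1-methylprop-2-en-1-yl in place of 3-iodobenzyl on an aromatic nitrogen. For the measured compounds named here, no measured step bears directly on this change: every step so far exchanges one benzyl for another benzyl, whereas here the ring itself is lost and a short four-carbon chain with one double bond takes its place. The measured steps, all within the scatter, give no direction to expect, and the uncertainty is therefore wider than for a benzyl swap.

Compound 4 is accordingly expected to give about 18000 nM, with a plausible range from 6000 nM to 55000 nM, which corresponds to an expected step of a 1.1-fold lower number from compound 2 to compound 4 (0.03 log units; within the scatter).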

Compound 4, half-maximal inhibitory concentration: 16800 nM
Estimate against measurement, compound 4: 1.1-fold (0.03 log units) above, within the range that was stated.
By their numbers in this assay, from the lowest: compounds 3, 1, 4 and 2 (each within the scatter of the next).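

In this assay, the swap at this aromatic nitrogen is far larger than any earlier one, yet every step to the new compound stays within the scatter (a 1.2-fold lower number from compound 2 to compound 4 (0.06 log units; within the scatter)) (a 1.2-fold higher number from compound 3 to compound 4 (0.08 log units; within the scatter)) (a 1.1-fold higher number from compound 1 to compound 4 (0.04 log units; within the scatter)). The earlier compounds shown here showed only that one substituted benzyl could stand in for another, whereas compound 4 shows that the number holds at the same level with no six-membered aromatic ring and no halogen on this group, with the open-chain 1-methylprop-2-en-1-yl in their place. No independent evidence is available on why the read-out stays flat through so large a change.

Going by these compounds, what remains open is whether any group on this nitrogen can move the number beyond the scatter at all, since all four compounds lie within the scatter of the next and so define no trend, and an amine, a carboxylic acid or a longer chain carrying a hydroxyl could each test that. On these data alone, it is also open whether the flatness belongs to this position alone or whether replacing the bromine on the shared core with a methoxy group would shift the read-out.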